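The source may report more compounds than this note shows. Statements on the series, on what has been measured and on what is new or still open speak of the compounds shown alone.

In a functional assay on CNE-2 cells (Homo sapiens) for antiproliferative activity, read by sulforhodamine B assay, with a stated time of 48 h (on this read-out lower numbers stand for stronger inhibition and higher numbers for weaker inhibition), compound 1 (`COc1ccc(/C=C/C(=O)c2ccccc2-c2ccc(OC)c(OC)c2)cc1OC`) gives 2500 nM and compound 2 (`COc1ccc(OC)c(/C=C/C(=O)c2ccccc2-c2ccc(OC)c(OC)c2)c1`) gives 2400 nM, a pair the scatter does not separate. Compound 3 (`COc1ccc(/C=C/C(=O)c2ccccc2-c2cccc(F)c2)cc1OC`) departs from compound 1 by 3-fluorophenyl in place of 3,4-dimethoxyphenyl on an aromatic carbon, on an aromatic carbon, ortho to a large group. For the measured compounds named here, the one measured step, a 1.0-fold lower number from compound 1 to compound 2 (0.02 log units; within the scatter), concerns a group on a double-bonded chain carbon, and no measured step touches this place. It offers only weak guidance, and no shift beyond the scatter is firmly expected in this assay. The expected step is a 1.2-fold higher number from compound 1 to compound 3 (0.08 log units; within the scatter). Compound 3 is estimated at 3000 nM, with an expected range of 1000 nM to 9000 nM.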

Compound 3, half-maximal inhibitory concentration: 650 nM
Compound 3: the middle estimate sits 4.6-fold (0.66 log units) above what was measured, and the stated range ends above it.
By their numbers in this assay, from the lowest: compound 3; then compounds 2 and 1 (each within the scatter of the next).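

In this assay the change to 3-fluorophenyl from 3,4-dimethoxyphenyl gives a 3.8-fold lower number from compound 1 to compound 3 (0.59 log units; beyond the scatter) and lies beyond the scatter, so this place on an aromatic carbon answers to substitution in a way the earlier pair did not show. The entering group has fewer heavy atoms and no hydrogen-bond acceptors, so the two methoxy groups of compound 1 are not needed for this level of inhibition. Nothing at hand says why the number moves. The compounds shown leave open whether the fluorine itself counts or a plain phenyl would read the same, and how an amine or a carboxylic acid on this ring would fare.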